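The source may hold more compounds than are shown below. What is called first, only, known or untested is meant among the compounds shown, and "the series" means these compounds.

Measured compounds and their values:

compound 1, `Cc1nc(C#Cc2cc(C#N)cc([N+](=O)[O-])c2)cs1` – 2.63 nM
compound 2, `Cc1nc(C#Cc2cc(Br)cc([N+](=O)[O-])c2)cs1` – 0.73 nM
compound 3, `Cc1nc(C#Cc2cc(Br)cc(C#N)c2)cs1` – 1.06 nM

All three share one core and differ only in the pair of groups on the six-membered aromatic ring of carbon only. In a functional assay on HEK293 cells for antagonist activity at metabotropic glutamate receptor 5 (Rattus norvegicus), read by calcium flux (on this read-out higher numbers stand for weaker inhibition and lower numbers for stronger inhibition), compound 2 gives the lowest number of the three. Compound 3 is close to it, a 1.5-fold higher number from compound 2 to compound 3 (0.16 log units; within the scatter), a gap that says nothing either way. Compound 1 is clearly apart: a 3.6-fold lower number from compound 1 to compound 2 (0.56 log units; beyond the scatter).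

Compound 4, `Cc1nc(C#Cc2cc(F)cc([N+](=O)[O-])c2)cs1`, is reached from compound 2 by one change: fluoro in place of bromo on an aromatic carbon. Going by the values given here, no measured step exchanges one halogen for another, so the guidance is indirect. The two steps that introduce bromo both lowered the number: a 3.6-fold lower number from compound 1 to compound 2 (0.56 log units; beyond the scatter) and a 2.5-fold lower number from compound 1 to compound 3 (0.39 log units; beyond the scatter). Removing bromo in favour of a different group might therefore cost some of that gain, though the size is uncertain.

Compound 4 is expected to give 2 nM in this assay, within 0.7 nM to 6 nM. This estimate means the step of a 2.7-fold higher number from compound 2 to compound 4 (0.44 log units; beyond the scatter), a modest rise expected for compound 4 relative to compound 2.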

Compound 4, half-maximal inhibitory concentration: 0.61 nM
Estimate against measurement, compound 4: 3.3-fold (0.52 log units) above; measured number below the stated range.
By their numbers in this assay, from the lowest: compounds 4, 2 and 3 (each within the scatter of the next); then compound 1.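

At this position of the shared core, with the nitro group kept, fluoro and bromo cannot be told apart in this assay (a 1.2-fold lower number from compound 2 to compound 4 (0.08 log units; within the scatter)), so a bromo group is not required for a low number here. Fluoro in place of cyano also gives a clear drop (a 4.3-fold lower number from compound 1 to compound 4 (0.63 log units; beyond the scatter)), which shows that the gain over compound 1 is not tied to bromo alone, since two quite different halogens both provide it. Nothing available explains why the two halogens behave alike, and no measured property bears on this result.

On these data alone, what a chloro group, a methyl group or an amine would do at this position remains open. So does whether fluoro would also match bromo with a nitrile rather than a nitro group on the ring, as in compound 3.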